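The compounds below may be only part of what the source reports. "The series", "measured", "known", "first", "only" and "open" are said of these compounds alone.

In a functional assay on the whole organism for antagonist activity, with Mus musculus as the target (a higher number here means that more compound is needed for the effect, a lower number that less compound is needed), compound 1 `CC1CCC(=O)N1CC#CCn1ccnc1` gives 1.1 mg/kg, and compound 2 `Cc1cncn1CC#CCN1C(=O)CCC1C` gives 1.4 mg/kg. The change between them is methyl in place of hydrogen on an aromatic carbon, and it made a step of a 1.3-fold higher number from compound 1 to compound 2 (0.10 log units; within the scatter). Compound 3 `CN(C)C(=O)N(C)CC#CCn1ccnc1` reaches only a limit in this assay, > 100 mg/kg. This is the limit of > 100 mg/kg in this assay, at which 1 of the 3 values shown sits. How the core of compound 3 differs from the core of compound 1 is not broken down here. Compound 4 `Cc1cncn1CC#CCN(C)C(=O)N(C)C` has not yet been measured in this assay; it differs from compound 3 by methyl in place of hydrogen on an aromatic carbon, the same change as from compound 1 to compound 2. Because the earlier step of a 1.3-fold higher number from compound 1 to compound 2 (0.10 log units; within the scatter) lay within the scatter, the expected step is a step that the limit leaves unreadable from compound 3 to compound 4. Compound 4 is therefore estimated at 150 mg/kg, with a likely range from 50 mg/kg to 600 mg/kg, and it is expected that this assay will most likely again report only a limit for compound 4.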

Compound 4, dose for half-maximal effect: 11.8 mg/kg
Beside the measured number, compound 4's estimate is 13-fold (1.10 log units) above it; the whole stated range lies above it.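

In this assay, methyl in place of hydrogen on an aromatic carbon made an at least 8.4-fold lower number from compound 3 to compound 4 (0.92 log units; beyond the scatter), so the change did not carry over from one core to the other with the same size: the same change on two cores in this assay, a 1.3-fold higher number (0.10 log units; within the scatter) from compound 1 to compound 2 and an at least 8.4-fold lower number (0.92 log units; beyond the scatter) from compound 3 to compound 4, at least 10-fold (1.03 log units) apart, beyond the scatter of two such steps

From the compounds shown here alone, the value of compound 3, > 100 mg/kg, is a limit and not a number, so the step on that core can be read only as a minimum and its full size stays unknown. Two cores do not make a rule, and these data do not show why the steps differ.

The compounds shown leave open whether an ethyl or a chlorine on that aromatic carbon would follow methyl on either core. Going by these compounds, how the methyl change would read on a further core also remains open.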